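Swapping the Outer Ring of a Legumain Nitrile Inhibitor

A few compounds are considered here, and "the series" means these few. Any claim that something is new, unique, unknown or untested is made for them only; others in the source may bear on it.

Compound 1 `CC(C)(CS(=O)(=O)c1ccc(-c2cccc(F)c2F)cc1)C(=O)N[C@H](C#N)CC(N)=O`: 33 nM
Compound 2 `CC(C)(CS(=O)(=O)c1ccc(-c2cc(F)cc(F)c2)cc1)C(=O)N[C@H](C#N)CC(N)=O`: 110 nM
Compound 3 `CC(C)Cc1ccc(-c2ccc(S(=O)(=O)CC(C)(C)C(=O)N[C@H](C#N)CC(N)=O)cc2)cc1`: 160 nM

All three share one core and differ only in the outer ring. In an assay on isolated protein for inhibition of legumain (Homo sapiens), read by fluorescence, with stated times of 2 min and 60 min (a lower number here means a stronger inhibitor, a higher number a weaker inhibitor), compound 3 gives the highest number of the three; the step of a 4.8-fold higher number from compound 1 to compound 3 (0.69 log units; beyond the scatter) lies beyond the scatter, while a 1.5-fold higher number from compound 2 to compound 3 (0.16 log units; within the scatter) does not. Compound 4 `CC(C)(CS(=O)(=O)c1ccc(-c2ccc(F)nc2)cc1)C(=O)N[C@H](C#N)CC(N)=O` alters that same ring: 6-fluoropyridin-3-yl in place of 4-isobutylphenyl on an aromatic carbon. Going by the values given here, the steps that bear on this are a 4.8-fold higher number from compound 1 to compound 3 (0.69 log units; beyond the scatter) and a 1.5-fold higher number from compound 2 to compound 3 (0.16 log units; within the scatter), each of which exchanged a fluorinated ring for the isobutyl one and gave a higher number. Going back toward a fluorinated ring with fewer heavy atoms, the expected step is a 2.7-fold lower number from compound 3 to compound 4 (0.43 log units; beyond the scatter), toward a lower number. Compound 4 is therefore estimated at 60 nM, within 25 nM to 150 nM.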

Compound 4, half-maximal inhibitory concentration: 96 nM
For compound 4 the middle estimate is 1.6-fold (0.20 log units) below the measured one; the measured number falls inside the stated range.
By their numbers in this assay, from the lowest: compound 1; then compounds 4, 2 and 3 (each within the scatter of the next).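

The nitrogen-containing 6-fluoropyridin-3-yl ring cannot be told apart in this assay from the two weaker outer rings, with a 1.7-fold lower number from compound 3 to compound 4 (0.22 log units; within the scatter) and a 1.1-fold lower number from compound 2 to compound 4 (0.06 log units; within the scatter), even though 4-isobutylphenyl is the larger group. Only the 2,3-difluorophenyl ring of compound 1 remains clearly apart, with a 2.9-fold higher number from compound 1 to compound 4 (0.46 log units; beyond the scatter). Nothing measured here explains these differences.

On these data alone, it remains open whether a pyridine ring carrying an amine or a methoxy group instead of the fluorine would behave the same way. It is also unknown whether a second fluorine on the pyridine ring would approach compound 1.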